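The compounds below may be only part of what the source reports. "The series", "measured", "known", "first", "only" and "open" are said of these compounds alone.

Measured so far:
- compound 1 `Cc1ccc2c(O)cc(-c3cccc(Cl)c3)nc2n1`: 10500 nM
- compound 2 `Cc1cnc2[nH]c(-c3cccc(Cl)c3)cc(=O)c2c1`: 15800 nM

In a functional assay on cells (Panel ovarian (Carcinoma cell lines), Homo sapiens) for inhibition (on this read-out lower numbers stand for stronger inhibition of growth and higher numbers for weaker inhibition of growth), compound 1 holds the lower of the two numbers, yet its gap to compound 2 is within the scatter, so the two compounds are not separated on this read-out.

Compound 3 `Cc1cc(C)c2c(O)cc(-c3cccc(Cl)c3)nc2n1` differs from compound 1 by methyl in place of hydrogen on an aromatic carbon. For the measured compounds named here, no measured pair covers a change of this kind, so the size of the step in this assay is open; the expectation is a shift no larger than the scatter, in either direction.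

For compound 3 the expected value in this assay is 8000 nM, within 3000 nM to 25000 nM, which means an expected step of a 1.3-fold lower number from compound 1 to compound 3 (0.12 log units; within the scatter).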

Compound 3, concentration for total growth inhibition: 30200 nM
Compound 3: the middle estimate sits 3.8-fold (0.58 log units) below what was measured, outside the stated range (above it).
By their numbers in this assay, from the lowest: compounds 1, 2 and 3 (each within the scatter of the next, the first and the last beyond it).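

In this assay, for the compounds shown here, the methyl on this aromatic carbon, opposite the ring nitrogen, is the first single-place change that can be read, giving a 2.9-fold higher number from compound 1 to compound 3 (0.46 log units; beyond the scatter) as a modest loss of growth inhibition. This position on the core of compound 1 therefore responds to a single added heavy atom. Nothing at hand explains the step.

On these data alone, whether an amine, a methoxy group or a chlorine on this carbon would move the number the same way stays open. A single step also leaves open how far the shift carries over to other members of the series.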